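Trifluoromethyl to fluoro on the shared core

The compounds below may be only part of what the source reports. "The series", "measured", "known", "first", "only" and "open" are said of these compounds alone.

Values in an ADME assay on microsomes from liver (Rattus norvegicus) for metabolic stability, with a stated time of 30 min; a higher number here means that more of the compound is left, a lower number that less of the compound is left:
compound 1 `CC(=O)N[C@@H](C)/C=C/c1ccc(Oc2ccc3nc(C(C)C)sc3c2Cl)nc1`: 52%
compound 2 `CC(=O)N[C@@H](C)/C=C/c1ccc(Oc2ccc3nc(C(C)C)sc3c2C(F)(F)F)nc1`: 83%
compound 3 `CC(=O)N[C@@H](C)/C=C/c1ccc(Oc2ccc3nc(C(C)C)sc3c2F)nc1`: not yet measured

Of the two measured compounds, compound 2 stands highest, at 83%. The next step, to compound 3, is fluoro in place of trifluoromethyl on an aromatic carbon. Within the data shown here, one measured step bears on it: a number 31 percentage points higher from compound 1 to compound 2 (beyond the scatter), a large step beyond the scatter, for trifluoromethyl in place of chloro on an aromatic carbon. Fluoro itself has no measurement in this series, so its standing against chloro is open. With trifluoromethyl leaving, a large step down is expected in this assay, of about the size of that measured step, which would bring the number near compound 1 at 52%. The expected step is a number 31 percentage points lower from compound 2 to compound 3 (beyond the scatter). Compound 3 is estimated at 52%, with an expected range of 32% to 74%.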

Compound 3, percent of the compound remaining: 51%
The estimate for compound 3 lay 1 percentage points above the measured number, within the range that was stated.
By their numbers in this assay, from the lowest: compounds 3 and 1 (each within the scatter of the next); then compound 2.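

In this assay, the step of a number 32 percentage points lower from compound 2 to compound 3 (beyond the scatter) shows that the gain at this position does not extend to fluoro, so it is not shared by every halogen-bearing group placed here. The step of a number 1 percentage points lower from compound 1 to compound 3 (within the scatter) leaves fluoro and chloro indistinguishable in this read-out, and among the three groups only trifluoromethyl stands apart. No data at hand account for the difference between trifluoromethyl and the two single halogens.

Open, from the compounds shown here alone, is how other groups at this position would compare with these three, such as methyl, methoxy or nitrile. Also open, going by these compounds, is whether the difference between trifluoromethyl and the two single halogens would hold if another part of the shared core were changed, as all three compounds carry the same remainder.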